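Carbamoyl to carboxy on the nitrile compound

The source may report more compounds than this note shows. Statements on the series, on what has been measured and on what is new or still open speak of the compounds shown alone.

Values in a functional assay on the whole organism with Rattus norvegicus as the target, at a dose of 25 mg/kg by the intravenous route (a lower number here means that less compound is needed, a higher number that more compound is needed for the effect), so far
- compound 1 `O=C(O)c1cc(NC(=O)c2ccc(-c3nn[nH]n3)cc2)cc(C(=O)O)c1` gives 1.2 mg/kg
- compound 2 `O=C(O)c1ccc(C(=O)Nc2cc(C(=O)O)cc(C(=O)O)c2)cc1` gives 2.1 mg/kg
- compound 3 `N#Cc1ccc(C(=O)Nc2cc(C(N)=O)cc(C(=O)O)c2)cc1` gives 5.7 mg/kg

Compound 3 (5.7 mg/kg) holds the highest of the three numbers, beyond the scatter of both others. Compound 4 `N#Cc1ccc(C(=O)Nc2cc(C(=O)O)cc(C(=O)O)c2)cc1` has hydroxy in place of amino on a carbonyl carbon, which reads as carbamoyl to carboxy. Going by the values given here, no measured step covers this change. Among the compounds with values here, the only measured step (a 1.8-fold higher number from compound 1 to compound 2 (0.24 log units; within the scatter)) concerns another group and stays within the scatter. Compound 4 would carry the carboxy groups also found in compound 1 (1.2 mg/kg) and compound 2 (2.1 mg/kg). A step to a lower number is therefore expected in this assay (a 2.9-fold lower number from compound 3 to compound 4 (0.45 log units; beyond the scatter)). For compound 4 the estimated value is 2 mg/kg (expected range 0.9 mg/kg to 4.5 mg/kg).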

Compound 4, dose for 50% inhibition: 1.7 mg/kg
The estimate for compound 4 lay 1.2-fold (0.07 log units) above the measured number; the range from low to high includes it.
By their numbers in this assay, from the lowest: compounds 1, 4 and 2 (each within the scatter of the next); then compound 3.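

In this assay, going by these compounds alone, carbamoyl to carboxy on the nitrile compound gives a 3.4-fold lower number from compound 3 to compound 4 (0.53 log units; beyond the scatter) and is the first step beyond the scatter, so this carbonyl carbon is sensitive to the change. With both carboxy groups present, cyano in place of carboxy gives a 1.2-fold lower number from compound 2 to compound 4 (0.09 log units; within the scatter) and cyano in place of 2H-tetrazol-5-yl gives a 1.4-fold higher number from compound 1 to compound 4 (0.15 log units; within the scatter) and neither step leaves the scatter.

Going by these compounds, whether a methyl ester or a hydroxamic acid on this carbonyl carbon would read like carboxy or like carbamoyl stays open. Nothing at hand gives a measured explanation for the carbamoyl to carboxy step.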